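A few compounds are considered here, and "the series" means these few. Any claim that something is new, unique, unknown or untested is made for them only; others in the source may bear on it.

In an assay on CHO cells for antagonist activity at transient receptor potential cation channel subfamily V member 1 (Homo sapiens), read by FLIPR (a higher number here means a weaker inhibitor, a lower number a stronger inhibitor), compound 3 `CC(C(=O)NCc1ccc(C(F)(F)F)cc1N1CCC(C(F)(F)F)CC1)c1ccc(NS(C)(=O)=O)c(F)c1` gives 0.4 nM, the lowest number among the three measured compounds; compound 2 `CCC1CCN(c2cc(C(F)(F)F)ccc2CNC(=O)C(C)c2ccc(NS(C)(=O)=O)c(F)c2)CC1` gives 0.7 nM and compound 1 `CC1CCN(c2cc(C(F)(F)F)ccc2CNC(=O)C(C)c2ccc(NS(C)(=O)=O)c(F)c2)CC1` gives 0.9 nM. Of the steps leading to it, a 1.8-fold lower number from compound 2 to compound 3 (0.24 log units; within the scatter) stays within the scatter, while a 2.3-fold lower number from compound 1 to compound 3 (0.35 log units; beyond the scatter) goes just beyond it. Compound 4 `CC(C(=O)NCc1ccc(C(F)(F)F)cc1N1CCC(c2ccc(F)cc2)CC1)c1ccc(NS(C)(=O)=O)c(F)c1` differs from compound 3 by 4-fluorophenyl in place of trifluoromethyl on a saturated ring carbon. The groups tried so far at this ring carbon have moved the numbers only a little, and the related growth step a 1.3-fold lower number from compound 1 to compound 2 (0.11 log units; within the scatter) also stayed within the scatter, so no step beyond the scatter is expected in this assay, though the new group is much larger than any tried. Compound 4 is therefore expected to give about 1 nM, between 0.3 nM and 4 nM. That estimate means a step of a 2.5-fold higher number from compound 3 to compound 4 (0.40 log units; beyond the scatter).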

Compound 4, inhibition constant: 0.9 nM
Compound 4: the middle estimate sits 1.1-fold (0.05 log units) above what was measured; the range from low to high includes it.
By their numbers in this assay, from the lowest: compounds 3, 2, 1 and 4 (each within the scatter of the next, the first and the last beyond it).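

In this assay this ring carbon takes a much larger group carrying an aromatic ring: 4-fluorophenyl, with 7 heavy atoms against 4 for trifluoromethyl, gives only a modest loss (a 2.3-fold higher number from compound 3 to compound 4 (0.35 log units; beyond the scatter)). Against the small alkyl groups, the aromatic ring brings no change beyond the scatter (a 1.3-fold higher number from compound 2 to compound 4 (0.11 log units; within the scatter); no change at the digits printed from compound 1 to compound 4 (within the scatter)). Nothing measured here explains these comparisons. Still open, on these data alone, is whether plain phenyl, without its fluorine, would give a similar number. Also open, as far as these compounds go, is how an amine or a carboxylic acid on this ring carbon would compare.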